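The source may hold more compounds than are shown below. What is called first, only, known or untested is meant among the compounds shown, and "the series" means these compounds.

Working notes on a small series measured in an assay on membranes from HeLa cells for displacement of a labelled ligand from adenosine receptor A3 (Homo sapiens), read by scintillation counting, with a stated time of 180 min, tested at 1 uM; a lower number here means less inhibition, a higher number more inhibition at the concentration tested (going by the name of the read-out).

Compound 1 `CC1=C(C(=O)CC(C)C)C(c2cccs2)NC(=O)N1` carries a thiophen-2-yl group; in this assay compound 1 gives 18%. Compound 2 `CCSC(=O)C1=C(C)NC(=O)NC1c1ccco1` carries a furan-2-yl group; in this assay compound 2 gives 14%. Compound 2 sits at the lower of the two numbers, but its gap to compound 1 lies within the scatter, so the two cannot be ordered.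

Compound 3 `CCSC(=O)C1=C(C)NC(=O)NC1c1cccs1` differs from compound 2 in one place: thiophen-2-yl in place of furan-2-yl on a saturated ring carbon. No measured pair shows this change on its own, and compound 1 differs from compound 3 in another place as well, so no step can be taken from the numbers shown. The step of a number 3 percentage points higher from compound 2 to compound 3 (within the scatter) is expected to be small, without a clear direction and not beyond the scatter. Compound 3 is therefore expected to give 17%, with a range from 4% to 32%.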

Compound 3, a percentage reported as inhibition, at one concentration (the size of the read-out at that concentration, not a potency): 1%
Compound 3: the middle estimate sits 16 percentage points above what was measured, outside the stated range (below it).
By their numbers in this assay, from the lowest: compound 3; then compounds 2 and 1 (each within the scatter of the next).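

In this assay, thiophen-2-yl in place of furan-2-yl on a saturated ring carbon gives a step beyond the scatter, a number 13 percentage points lower from compound 2 to compound 3 (beyond the scatter), even though the two groups have the same counts of heavy atoms, hydrogen-bond donors and hydrogen-bond acceptors and differ only in sulfur against oxygen. The group on the carbonyl carbon also matters with thiophen-2-yl held constant: ethylsulfanyl in place of isobutyl gives a number 17 percentage points lower from compound 1 to compound 3 (beyond the scatter). Nothing available explains either step.

From the compounds shown here alone, whether the change from furan-2-yl to thiophen-2-yl has the same direction and size with isobutyl on the carbonyl carbon remains open. So does the reading with a phenyl group on the saturated ring carbon, or with a longer chain in place of ethylsulfanyl.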